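The source may hold more compounds than are shown below. What is called first, only, known or untested is meant among the compounds shown, and "the series" means these compounds.

Measured so far in a functional assay on HeLa cells (Homo sapiens) for inhibition, read by CCK-8 assay, with a stated time of 48 h; on this read-out higher numbers stand for weaker inhibition and lower numbers for stronger inhibition:
- Compound 1 `COc1cc(-c2cc3nccc(-c4cc(OC)c(OC)c(OC)c4)n3n2)cc(OC)c1OC`: > 10000 nM, a limit of the assay and not a number
- Compound 2 `COc1cc(-c2ccnc3cc(-c4ccc(C)cc4)nn23)cc(OC)c1OC`: 21 nM
- Compound 3 `COc1cc(-c2ccnc3cc(-c4ccccc4)nn23)cc(OC)c1OC`: 458 nM

Of the two actual numbers, compound 3 has the higher, making it the weaker inhibitor of that pair. Compound 4 `COc1cc(-c2ccnc3cc(-c4ccc(N(C)C)cc4)nn23)cc(OC)c1OC` differs from compound 3 in one place: dimethylamino in place of hydrogen on an aromatic carbon. This turns phenyl into 4-(dimethylamino)phenyl. For the measured compounds named here, the one measured step that bears on this change is hydrogen in place of methyl on an aromatic carbon, a 22-fold higher number from compound 2 to compound 3 (1.34 log units; beyond the scatter). Read in reverse, that large step shows a lower number when the group is present. Methyl is not dimethylamino, so a lower number in this assay is expected, but a smaller step. The expected step is a 7.6-fold lower number from compound 3 to compound 4 (0.88 log units; beyond the scatter). Compound 4 is estimated at 60 nM, with an expected range of 10 nM to 350 nM.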

Compound 4, half-maximal inhibitory concentration: 378 nM
Compound 4: middle estimate off by 6.3-fold (0.80 log units), on the low side, outside the stated range (above it).
By their numbers in this assay, from the lowest: compound 2; then compounds 4 and 3 (each within the scatter of the next). At a limit, above all of these: compound 1.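

In this assay, dimethylamino on the aromatic carbon para to a large group gives a 1.2-fold lower number from compound 3 to compound 4 (0.08 log units; within the scatter) and so does not repeat what methyl does at that place. Replacing methyl with dimethylamino there gives an 18-fold higher number from compound 2 to compound 4 (1.26 log units; beyond the scatter) and shows that the low number of compound 2 is not shared by every group placed there. What sets these two groups apart cannot be told from the measurements at hand. From the compounds shown here alone, whether ethyl, methoxy or a chlorine atom at this place would follow methyl or dimethylamino stays open.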